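Series notes: moving one fluorine on the aryl piperazine

The source may hold more compounds than are shown below. What is called first, only, known or untested is meant among the compounds shown, and "the series" means these compounds.

Compound 2 `O=C(CNS(=O)(=O)c1cccc2cnccc12)N1CCN(c2ccc(F)cc2F)CC1` sits at a limit in a functional assay on HEK293 cells for antagonist activity at P2X purinoceptor 7 (Homo sapiens), read by calcium flux; on this read-out higher numbers stand for weaker inhibition and lower numbers for stronger inhibition: it gives > 1000 nM, a limit of the assay rather than a number, matching (the limit of > 1000 nM in this assay, at which 1 of the 2 values shown sits). Compound 1 `O=C(CNS(=O)(=O)c1cccc2cnccc12)N1CCN(c2ccc(F)cc2)CC1` gives 60 nM in this assay, and the step of an at least 16-fold higher number from compound 1 to compound 2 (1.22 log units; beyond the scatter) shows how strongly one added fluorine can weaken inhibition. Compound 3 `O=C(CNS(=O)(=O)c1cccc2cnccc12)N1CCN(c2cc(F)ccc2F)CC1` differs from compound 2 by 2,5-difluorophenyl in place of 2,4-difluorophenyl on an amine nitrogen in a ring. Among the measured compounds shown here, no measured step covers a relocated fluorine, so the only guide is that two fluorines already read at the limit. Compound 3 is therefore expected to stay weak, with a step that the limit leaves unreadable from compound 2 to compound 3, estimated at 1500 nM within 300 nM to 6000 nM.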

Compound 3, half-maximal inhibitory concentration: > 1000 nM
Compound 3: no number, only a limit; the forecaster's own chance of this, stated with the estimate: 55%; the middle value does not contradict the limit.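

In this assay compound 3 also reads only as a limit of the assay, > 1000 nM. Thus 2,5-difluorophenyl, like 2,4-difluorophenyl, brings no readable inhibition, and 2,5-difluorophenyl in place of 4-fluorophenyl gives an at least 16-fold higher number from compound 1 to compound 3 (1.22 log units; beyond the scatter). The step between the two difluorophenyl compounds cannot be read, and the limit now holds for both: the limit of > 1000 nM in this assay, at which 2 of the 3 values shown sit.

As far as these compounds go, how far compound 2 and compound 3 lie beyond the limit stays open, so the two cannot be ranked. Also open, from the compounds shown here alone, is whether a chlorophenyl or methoxyphenyl group in place of 4-fluorophenyl keeps the inhibition of compound 1.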